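A terminal hydroxy gives way to a methylpiperidine

The source may hold more compounds than are shown below. What is called first, only, known or untested is meant among the compounds shown, and "the series" means these compounds.

compound 1 `CC(C)CCSc1nc(C(F)(F)F)ccc1CNC(=O)C(C)c1ccc(NS(C)(=O)=O)c(F)c1`: 0.7 nM
compound 2 `CC(C(=O)NCc1ccc(C(F)(F)F)nc1SCCCO)c1ccc(NS(C)(=O)=O)c(F)c1`: "not active" (no number reported)

In an assay on CHO-K1 cells for antagonist activity at transient receptor potential cation channel subfamily V member 1 (Homo sapiens), read by FLIPR (a higher number here means a weaker inhibitor, a lower number a stronger inhibitor), compound 1 gives 0.7 nM. In this assay, within the data shown here, compound 2 is reported only as "not active" (no number reported), so no single number tells where compound 2 stands, and no counted step can be drawn from it. Compound 3 `CC1CCN(CCCSc2nc(C(F)(F)F)ccc2CNC(=O)C(C)c2ccc(NS(C)(=O)=O)c(F)c2)CC1` differs from compound 2 by 4-methylpiperidin-1-yl in place of hydroxy on a saturated chain carbon, three bonds along the chain from a sulfur. With no number for compound 2, the step itself cannot be sized, but a move toward stronger inhibition, beyond the usual scatter, is expected. Compound 3 is estimated to give 30 nM in this assay, with a range from 3 nM to 300 nM.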

Compound 3, inhibition constant: 2.9 nM
The estimate for compound 3 lay 10-fold (1.01 log units) above the measured number; the measured number lies below the stated range.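

In this assay compound 3 gives 2.9 nM, which shows that this chain on the sulfur can end in a 4-methylpiperidin-1-yl ring and still hold strong inhibition. The exchange of isopropyl for (4-methylpiperidin-1-yl)methyl weakens inhibition only modestly (a 4.1-fold higher number from compound 1 to compound 3 (0.62 log units; beyond the scatter)). The step from compound 2 cannot be read, since compound 2 has no number.

Going by these compounds, whether a morpholine, a piperazine, an unsubstituted piperidine or a shorter chain would fare the same remains open. Nothing shown explains these differences.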